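A few compounds are considered here, and "the series" means these few. Any claim that something is new, unique, unknown or untested is made for them only; others in the source may bear on it.

Compound 2 `CCCCCCc1cn(Cc2cc(=O)oc3cc(O)ccc23)nn1` is the starting point. In a functional assay on CFPAC-1 cells (Homo sapiens) for inhibition, read by MTT assay, with a stated time of 72 h (a higher number here means a weaker inhibitor, a lower number a stronger inhibitor), compound 2 gives > 100000 nM, which is a limit of the assay rather than a number. Compound 1 `O=c1cc(Cn2cc(CCCO)nn2)c2ccc(O)cc2o1` is the nearest measured neighbour. In this assay compound 1 gives > 100000 nM, again a limit. The step that the two limits leave unreadable from compound 1 to compound 2 therefore cannot be read, because of the limit of > 100000 nM in this assay, at which 2 of the 2 values shown sit. Compound 3 `O=c1cc(Cn2cc(-c3ccc(Br)cc3)nn2)c2ccc(O)cc2o1` differs from compound 2 by 4-bromophenyl in place of hexyl on an aromatic carbon. Within the data shown here, no measured step bears on this change, so the size of a number no higher from compound 2 to compound 3 (the limit leaves the size open) is an expectation with little support. Compound 3 is expected to give about 100000 nM, within 20000 nM to 300000 nM.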

Compound 3, half-maximal inhibitory concentration: 52900 nM
For compound 3 the middle estimate is 1.9-fold (0.28 log units) above the measured one, and the stated range covers the measured number.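

Among the groups shown on this aromatic carbon, 4-bromophenyl is the first to give a measured number in this assay rather than a limit. Putting it in place of the chains gives an at least 1.8-fold lower number from compound 2 to compound 3 (0.27 log units; that floor lies within the scatter) and an at least 1.8-fold lower number from compound 1 to compound 3 (0.27 log units; that floor lies within the scatter). Both steps are only floors, so their full size stays unknown: the limit of > 100000 nM in this assay, at which 2 of the 3 values shown sit.

The compounds shown leave open whether the ring or the bromine goes with this number. They also leave open how a plain phenyl would read, or a phenyl with an amine or a carboxylic acid in place of the bromine.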